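Urea in place of isopropyl amide on the pyrrolidine series

The compounds below may be only part of what the source reports. "The series", "measured", "known", "first", "only" and "open" are said of these compounds alone.

Within the data shown here, compound 3 `CC(C)C(=O)N[C@H]1CCN(c2cccc3oc(CCCCc4ccccc4)cc23)C1` gives the highest number of the three measured so far in an assay on NIH3T3 cells for binding affinity to melatonin receptor type 1B (Homo sapiens) (on this read-out higher numbers stand for weaker inhibition and lower numbers for stronger inhibition), 162 nM. Compound 1 `CC(=O)NCCCc1cccc2oc(CCCCc3ccccc3)cc12` gives 127 nM and compound 2 `CC(=O)N[C@H]1CCN(c2cccc3oc(CCCCc4ccccc4)cc23)C1` gives 14 nM. The two steps are a 9.1-fold lower number from compound 1 to compound 2 (0.96 log units; beyond the scatter) and a 12-fold higher number from compound 2 to compound 3 (1.06 log units; beyond the scatter). Compound 4 `CCNC(=O)N[C@H]1CCN(c2cccc3oc(CCCCc4ccccc4)cc23)C1` differs from compound 3 by ethylamino in place of isopropyl on a carbonyl carbon. Among the measured compounds shown here, the only step that bears on this position is the one from compound 2 to compound 3, where the larger acyl group brought a large loss; ethylamino keeps the size of isopropyl but adds a donor, so no measured step truly covers it. For compound 4 a modest gain is expected, a 2.7-fold lower number from compound 3 to compound 4 (0.43 log units; beyond the scatter), giving an estimated 60 nM with a range of 15 nM to 250 nM.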

Compound 4, inhibition constant: 98 nM
Estimate against measurement, compound 4: 1.6-fold (0.21 log units) below; the range from low to high includes it.
By their numbers in this assay, from the lowest: compound 2; then compounds 4, 1 and 3 (each within the scatter of the next).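

Ethylamino and isopropyl on this carbonyl carbon are not told apart, with a 1.7-fold lower number from compound 3 to compound 4 (0.22 log units; within the scatter) as the step, so the hydrogen-bond donor that ethylamino brings shows no separable effect here. Methyl stays ahead of ethylamino, with a 7.0-fold higher number from compound 2 to compound 4 (0.85 log units; beyond the scatter) as the step, and compound 2 keeps the lowest number in the pyrrolidine series. No evidence on the reason for either step is available.

Open, on these data alone, is whether methylamino or methoxy on this carbonyl carbon would come back towards compound 2. Also open, as far as these compounds go, is how a longer chain such as propylamino would compare with ethylamino.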